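A few compounds are considered here, and "the series" means these few. Any claim that something is new, unique, unknown or untested is made for them only; others in the source may bear on it.

Compound 1, `CN(C)CCCN1CCN(CC(=O)Nc2ccc(-c3nc4cc(F)ccc4o3)cc2)CC1`, gives 21900 nM. Compound 2, `Cc1ccc2oc(-c3ccc(NC(=O)CN4CCN(CCCN(C)C)CC4)cc3)nc2c1`, gives 26400 nM. Compound 3, `Cc1ccc2oc(-c3ccc(NC(=O)CCl)cc3)nc2c1`, gives 11600 nM.

All three were measured in an ADME assay on NIH3T3 cells (Mus musculus) for cytotoxicity, read by MTT assay, with a stated time of 24 h; on this read-out higher numbers stand for weaker inhibition and lower numbers for stronger inhibition. Compound 1 and compound 2 share a core that differs from the core of compound 3; that difference is not broken down here, and the two sets of values are simply placed side by side. Between compound 2 and compound 1 the single change is fluoro in place of methyl on an aromatic carbon, and it moved the number by a 1.2-fold lower number from compound 2 to compound 1 (0.08 log units; within the scatter). Compound 3 sits at the lowest of the three numbers, though its gap to compound 1 lies within the scatter, while its gap to compound 2 lies beyond it.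

Compound 4, `O=C(CCl)Nc1ccc(-c2nc3cc(F)ccc3o2)cc1`, has not yet been measured. It differs from compound 3 by fluoro in place of methyl on an aromatic carbon, the same change that separates compound 2 from compound 1. Because the earlier step was a 1.2-fold lower number from compound 2 to compound 1 (0.08 log units; within the scatter), the expectation for compound 4 in this assay is a step of similar size, a 1.2-fold lower number from compound 3 to compound 4 (0.06 log units; within the scatter), starting from compound 3 at 11600 nM. This rests on a single precedent, so the range is kept broad. Compound 4 is therefore expected to give about 10000 nM, with an estimated span from 5000 nM to 22000 nM.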

Compound 4, half-maximal inhibitory concentration: 9190 nM
For compound 4 the middle estimate is 1.1-fold (0.04 log units) above the measured one; low and high end bracket the measured number.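

In this assay, putting fluoro in place of methyl on an aromatic carbon of the core of compound 3 gave a 1.3-fold lower number from compound 3 to compound 4 (0.10 log units; within the scatter), so this step on its own gives no evidence that the swap matters on this core. Set beside the earlier step, the change behaved alike on the two cores, with no difference between them that can be told from the scatter: the same change on two cores in this assay, a 1.2-fold lower number (0.08 log units; within the scatter) from compound 2 to compound 1 and a 1.3-fold lower number (0.10 log units; within the scatter) from compound 3 to compound 4, 1.0-fold (0.02 log units) apart, within the scatter of two such steps This shows that, in this cytotoxicity read-out, the swap carried over from one core to the other without any visible departure, but it does not show that fluoro and methyl differ at this place, since neither step lies beyond the scatter, and two cores are too few to support a rule for the wider series.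

The compounds shown leave open what a group other than methyl or fluoro, such as methoxy, chloro or a nitrile, would do on that same aromatic carbon, and whether a step beyond the scatter can be found there at all. They also leave open whether the agreement would last on a core whose side chain ends in a carboxylic acid, or in a longer chain than those present here.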